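This account rests on a few compounds, and the source may have more. Where it says the series, first, only, none or still open, it means among the compounds named here.

Within the data shown here, compound 1 `COc1cccc(C(=O)N(C)/N=C/c2ccc(OC)c(OC)c2)c1` is one of two compounds measured in a functional assay on the whole organism (strain A/J) for inhibition, with Mus musculus as the target, with stated times of 1 h and 18 h, at a dose of 100 umol/kg by the oral route (on this read-out higher numbers stand for more inhibition at the one dose given (going by the name of the read-out) and lower numbers for less inhibition), and in that assay compound 1 gives 38%, the lower of the two numbers. Among the measured compounds shown here, its only measured neighbour is compound 2 `COc1ccc(/C=N/N(C)C(=O)c2ccc(OC)c(OC)c2)cc1OC`, which in this assay gives 65%. For the measured compounds named here, the single measured step, a number 27 percentage points higher from compound 1 to compound 2 (beyond the scatter), goes with a methoxy in place of hydrogen on an aromatic carbon, so in this pair gaining a methoxy went together with more inhibition. Compound 3 `COc1ccc(/C=N/N(C)C(=O)c2ccccc2)cc1OC` has not yet been measured; it differs from compound 1 by hydrogen in place of methoxy on an aromatic carbon. Going by the values given here, this is a change of the same kind taken the other way: a methoxy is lost rather than gained, and at a different aromatic carbon, so the one measured step is only a loose guide. If the loss of a methoxy acts like the gain in reverse, the inhibition of compound 3 is expected to fall by a modest amount, the expected step being a number 13 percentage points lower from compound 1 to compound 3 (beyond the scatter). Compound 3 is therefore estimated at 25%, with a range from 5% to 45%.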

Compound 3, a percentage reported as inhibition, in the whole organism at one dose (the size of the read-out at that dose, not a potency): 53%
Compound 3: middle estimate off by 28 percentage points, on the low side; measured number outside the range, above it.
By their numbers in this assay, from the lowest: compound 1; then compound 3; then compound 2.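

In this assay, putting hydrogen in place of the methoxy that sits meta to a large group, the change from 3-methoxyphenyl to phenyl, gives a number 15 percentage points higher from compound 1 to compound 3 (beyond the scatter), so inhibition in this pair does not depend on that methoxy and is in fact greater without it. The earlier step, a number 27 percentage points higher from compound 1 to compound 2 (beyond the scatter), also raised the number, but by gaining a methoxy at a different aromatic carbon, so among these compounds gaining one methoxy and losing another both go with more inhibition, and the simple count of methoxy groups does not order the results. No measurement given here bears on why a methoxy goes with less inhibition in one place and more in another.

The compounds shown have only methoxy or hydrogen at this aromatic carbon, so it remains open whether the gain comes from losing the methoxy itself or would also appear with another group there, such as fluorine, an amine, a carboxylic acid or a longer ethoxy chain. Each number also comes from a single dose, which leaves potency open.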